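The source may report more compounds than this note shows. Statements on the series, on what has been measured and on what is new or still open speak of the compounds shown alone.

Compounds measured in a functional assay on BJAB cells (Homo sapiens) for antiproliferative activity, with a stated time of 4 days; a lower number here means that less compound is needed, a higher number that more compound is needed for the effect:
compound 1 `Cc1nn(-c2nc(-c3ccc(Cl)c(Cl)c3)c(SC(C)C)s2)c(C(=O)O)c1-c1cncc(C#N)c1`, 20000 nM
compound 3 `Cc1c(-c2cc(Cl)cc(Cl)c2)c(C(=O)O)nn1-c1nc(-c2cc(Cl)cc(Cl)c2)c(SC(C)C)s1`, 2000 nM
compound 2 `Cc1oncc1-c1nc(-n2nc(C(=O)O)c(-c3cc(Cl)cc(Cl)c3)c2C)sc1SC(C)C`, for which this assay gives only a limit, > 44000 nM

Among the two numbers, compound 1 stands highest, with compound 3 nearest below it. The measured step of note is an at least 22-fold lower number from compound 2 to compound 3 (1.34 log units; beyond the scatter), a large move toward a lower number when a carbon-only ring replaces a heteroaryl ring. Compound 4 `Cc1nn(-c2nc(-c3ccc(Cl)c(Cl)c3)c(SC(C)C)s2)c(C(=O)O)c1-c1ccc(C(F)(F)F)cc1` has not yet been measured. Its change from compound 1 is 4-(trifluoromethyl)phenyl in place of 5-cyanopyridin-3-yl on an aromatic carbon, again a carbon-only ring entering where a heteroaryl ring leaves, although at a different place in the core than in the step from compound 2 to compound 3. Therefore the expected step is estimated as a 3.3-fold lower number from compound 1 to compound 4 (0.52 log units; beyond the scatter), a move toward a lower number in this assay but of smaller size than the measured one. For compound 4 the expected value is 6000 nM, within 2000 nM to 20000 nM.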

Compound 4, half-maximal effective concentration: 3500 nM
Estimate against measurement, compound 4: 1.7-fold (0.23 log units) above, within the range that was stated.
By their numbers in this assay, from the lowest: compounds 3 and 4 (each within the scatter of the next); then compound 1. At a limit, above all of these: compound 2.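

In this assay, the aromatic carbon next to the ring atom that bears a carboxy group proves sensitive to its substituent: 4-(trifluoromethyl)phenyl in place of 5-cyanopyridin-3-yl gives a 5.7-fold lower number from compound 1 to compound 4 (0.76 log units; beyond the scatter) in a modest step. The earlier compounds shown here showed a carbon-only ring lowering the number only at another place in the core, and this step shows the same direction here. Nothing shown gives a cause for this step. The compounds shown do not separate the ring nitrogen, the nitrile and the trifluoromethyl from one another. Going by these compounds, how a plain phenyl or an amine would read at this position remains open.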